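The compounds below may be only part of what the source reports. "The series", "measured", "known", "first", "only" and "open" are said of these compounds alone.

Measured compounds:
compound 1, `CN(C)CCCCC(=O)Nc1ccc(CN2N=C(c3ccc(F)cc3)C3C=CC=CC3C2=O)cc1`, 77700 nM
compound 2, `COc1ccc(-c2nn(Cc3ccc(NC(=O)OCCCCN(C)C)cc3)c(=O)c3ccccc23)cc1`, 20300 nM

In an ADME assay on Huh-7 cells (Homo sapiens) for cytotoxicity, read by MTT assay, with a stated time of 48 h (a higher number here means that more compound is tolerated, a lower number that less compound is tolerated), compound 2 gives the lower of the two numbers shown, and its gap to compound 1 lies beyond the scatter. Compound 3, `CN(C)CCCCOC(=O)Nc1ccc(Cn2nc(-c3ccccc3C#N)c3ccccc3c2=O)cc1`, has not yet been measured. It differs from compound 2 in one place: 2-cyanophenyl in place of 4-methoxyphenyl on an aromatic carbon. Among the measured compounds shown here, no measured pair shows what such a change does here, so the step from compound 2 to compound 3 is expected to be small, not beyond the scatter, with no direction assumed: a 1.2-fold higher number from compound 2 to compound 3 (0.09 log units; within the scatter). Compound 3 is therefore estimated at 25000 nM, within 8000 nM to 70000 nM.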

Compound 3, half-maximal cytotoxic concentration: 90700 nM
Compound 3: middle estimate off by 3.6-fold (0.56 log units), on the low side, outside the stated range (above it).
By their numbers in this assay, from the lowest: compound 2; then compounds 1 and 3 (each within the scatter of the next).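

In this assay this aromatic carbon, next to the ring nitrogen, proves sensitive to the group it carries: 2-cyanophenyl in place of 4-methoxyphenyl gives a 4.5-fold higher number from compound 2 to compound 3 (0.65 log units; beyond the scatter) and so more compound is tolerated. The two groups have the same count of heavy atoms and of hydrogen-bond acceptors, so those counts alone do not set the number. No measurement shown here accounts for the step.

The compounds shown leave open whether the change comes from gaining the nitrile, from its place on the phenyl ring or from losing the methoxy group. A plain phenyl group, or a nitrile moved elsewhere on that ring, would help to separate these.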